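The source may hold more compounds than are shown below. What is called first, only, known or untested is meant among the compounds shown, and "the series" means these compounds.

In a functional assay on Raji cells (Homo sapiens) for antiproliferative activity, read by MTT assay, with a stated time of 6 days (a higher number here means a weaker inhibitor, a lower number a stronger inhibitor), compound 1 `CC(=O)O[C@@H]1C=CC(=O)O[C@@H]1[C@@H](COC(=O)c1ccc([N+](=O)[O-])cc1)OC(C)=O` gives 18500 nM, compound 2 `O=C1C=C[C@@H](OCc2ccccc2)[C@@H]([C@@H](COC(=O)/C=C/c2ccccc2)OCc2ccccc2)O1` gives 1330 nM and compound 3 `COc1ccc(/C=C/C(=O)OC[C@@H](OCc2ccccc2)[C@H]2OC(=O)C=C[C@H]2OCc2ccccc2)cc1` gives 690 nM. Compound 2 thus stands well under compound 1 and within the scatter of compound 3, so these two form a group at the lower end of the three numbers.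

Compound 4 `O=C1C=C[C@@H](OCc2ccccc2)[C@@H]([C@@H](COC(=O)/C=C/c2ccc(F)cc2)OCc2ccccc2)O1` differs from compound 2 at one place: fluoro in place of hydrogen on an aromatic carbon. This is fluoro in place of hydrogen on an aromatic carbon. Among the measured compounds shown here, one measured step bears on this change, as it also replaces hydrogen on an aromatic carbon, there with methoxy: a 1.9-fold lower number from compound 2 to compound 3 (0.29 log units; within the scatter). For the measured compounds named here, no measured compound carries fluoro, so this single step is the only guide. Since that step, a 1.9-fold lower number from compound 2 to compound 3 (0.29 log units; within the scatter), does not leave the scatter, no step beyond the scatter is expected in this assay, and no direction can be firmly expected. The expected step is a 1.2-fold lower number from compound 2 to compound 4 (0.08 log units; within the scatter). For compound 4 the estimated value is 1100 nM, with an expected range from 450 nM to 2700 nM.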

Compound 4, half-maximal inhibitory concentration: 2470 nM
For compound 4 the middle estimate is 2.2-fold (0.35 log units) below the measured one; the range from low to high includes it.
By their numbers in this assay, from the lowest: compounds 3, 2 and 4 (each within the scatter of the next, the first and the last beyond it); then compound 1.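

In this assay, fluoro on the aromatic carbon para to a large group gives a 1.9-fold higher number from compound 2 to compound 4 (0.27 log units; within the scatter), so fluoro, like methoxy before it, is not told apart from hydrogen at this place. Among the compounds shown here, what the earlier compounds could not show is the comparison of the two groups with each other: fluoro in place of methoxy gives a 3.6-fold higher number from compound 3 to compound 4 (0.55 log units; beyond the scatter), a modest step, so this place does respond to the choice of group even though neither group leaves the scatter of hydrogen. Nothing available here accounts for this difference.

From the compounds shown here alone, it remains open whether an amine or a carboxylic acid at this place would carry the number beyond the scatter of compound 2. Going by these compounds, it is also open whether a longer chain such as ethoxy would read like methoxy in compound 3.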